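A few compounds are considered here, and "the series" means these few. Any claim that something is new, unique, unknown or untested is made for them only; others in the source may bear on it.

Compound 1, `CNC(=O)c1cc(C(=O)NC2CC2)cn([C@H](C)c2ccccc2)c1=O`: >= 168 ug/mL
Compound 2, `CNC(=O)c1cc(C(=O)NC2CCC2)cn(Cc2ccncc2)c1=O`: >= 118 ug/mL
Compound 3, `CNC(=O)c1cc(C(=O)NCCC(C)C)cn(Cc2ccccc2)c1=O`: 10 ug/mL

Of the compounds shown here, three built on one shared core have been tested in a physicochemical assay for solubility; on this read-out lower numbers stand for lower solubility and higher numbers for higher solubility. Compound 1 gives >= 168 ug/mL, which is a limit of the assay rather than a measured number. Compound 2 likewise gives >= 118 ug/mL, again only a limit. Compound 3 gives 10 ug/mL, a plain number. Among the values shown, compound 1 therefore stands at the upper edge of what this assay reports, at the limit of >= 168 ug/mL in this assay, at which 1 of the 3 values shown sits, and how far it truly reaches is not known. For the measured compounds named here, no pair of measured compounds differs in only one place, so no measured step can be drawn between them.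

Compound 4, `CNC(=O)c1cc(C(=O)NC2CC2)cn(CC2CCOCC2)c1=O`, has not yet been measured. It differs from compound 1 in one place: (oxan-4-yl)methyl in place of 1-phenylethyl on an aromatic nitrogen. Since compound 1 already sits at a limit, any step from it cannot be measured precisely; the step from compound 1 to compound 4 is expected to be a step that the limit leaves unreadable from compound 1 to compound 4, that is, none beyond the usual scatter. Compound 4 is accordingly estimated to give about 200 ug/mL, somewhere between 80 ug/mL and 500 ug/mL, and most probably this assay will once more report only a limit for it.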

Compound 4, solubility: >= 165 ug/mL
Compound 4: only a limit was reported; the forecaster's own chance of this, stated with the estimate: 70%; the middle value does not contradict the limit.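

Compound 1 and compound 4 are both reported in this assay only as limits, so the step between them cannot be read. The compounds shown leave open how far the true values of compound 1 and compound 4 reach, and so whether (oxan-4-yl)methyl in place of 1-phenylethyl on the aromatic nitrogen changes the read-out at all.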